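The source may hold more compounds than are shown below. What is called first, only, known or untested is meant among the compounds shown, and "the series" means these compounds.

Of the compounds shown here, three that share one core have been tested in a functional assay on DU-145 cells (Homo sapiens) for antiproliferative activity, read by MTT assay, with a stated time of 72 h; on this read-out higher numbers stand for weaker inhibition and lower numbers for stronger inhibition. Compound 1 `O=C(COc1ccc(C(=O)/C=C/c2ccc(Cl)cc2Cl)cc1)N[C@H]1CCOC1=O` gives 8610 nM. Compound 2 `CC(C)c1ccc(/C=C/C(=O)c2ccc(OCC(=O)N[C@H]3CCOC3=O)cc2)cc1` gives 13100 nM. Compound 3 `O=C(COc1ccc(C(=O)/C=C/c2cccc(Br)c2)cc1)N[C@H]1CCOC1=O` gives 9800 nM. On these numbers compound 3 stands second highest of the three; the nearest number is reached by a 1.1-fold higher number from compound 1 to compound 3 (0.06 log units; within the scatter), the furthest by a 1.3-fold lower number from compound 2 to compound 3 (0.13 log units; within the scatter). Among the compounds with values here, the three compounds differ only in the aromatic group on the double-bonded chain carbon, and the remaining swap, a 1.5-fold higher number from compound 1 to compound 2 (0.18 log units; within the scatter), likewise stays within the scatter, so nothing so far separates these aromatic groups in this assay.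

Compound 4 `O=C(COc1ccc(C(=O)/C=C/c2ccccc2)cc1)N[C@H]1CCOC1=O` has not yet been measured. It differs from compound 3 by hydrogen in place of bromo on an aromatic carbon. Within the data shown here, the steps that bear on this are the ones that also change only this aromatic group: since a 1.1-fold higher number from compound 1 to compound 3 (0.06 log units; within the scatter) and a 1.3-fold lower number from compound 2 to compound 3 (0.13 log units; within the scatter) both stay within the scatter, the expectation for compound 4 in this assay is again no step beyond the scatter in either direction. The estimated change is a 1.0-fold higher number from compound 3 to compound 4 (0.01 log units; within the scatter). Compound 4 is therefore expected to give about 10000 nM in this assay, with a likely range from 5000 nM to 20000 nM.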

Compound 4, half-maximal inhibitory concentration: 48300 nM
Compound 4: the middle estimate sits 4.8-fold (0.68 log units) below what was measured, and the stated range ends below it.
By their numbers in this assay, from the lowest: compounds 1, 3 and 2 (each within the scatter of the next); then compound 4.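

Taking the substituent off the aromatic ring altogether is the first change in this series to move the number in this assay beyond the scatter, with a 4.9-fold higher number from compound 3 to compound 4 (0.69 log units; beyond the scatter), a 3.7-fold higher number from compound 2 to compound 4 (0.57 log units; beyond the scatter) and a 5.6-fold higher number from compound 1 to compound 4 (0.75 log units; beyond the scatter). The 3-bromophenyl, 4-isopropylphenyl and 2,4-dichlorophenyl compounds could not be told apart, yet each is clearly stronger than the plain phenyl compound, so among these four compounds what counts is that the ring carries some group other than hydrogen, far more than which of these groups it is. Nothing measured here accounts for this drop in inhibition, so the reason remains unknown.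

The compounds shown leave open whether a group as small as fluoro or methyl would be enough to restore the stronger numbers, or whether an amine or a carboxylic acid on the ring would do the same. Because each substituted compound changes both the group and its place on the ring, they also leave open whether bromo would give a similar number at another ring position.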